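The compounds below may be only part of what the source reports. "The series", "measured", "known", "first", "only" and "open" are said of these compounds alone.

The series shares one core, seen first in compound 1 `CCOC(=O)c1c(-c2cccc(OC)c2)[nH]c2cc(OC)ccc2c1=O`. In an ADME assay on BJ cells (Homo sapiens) for cytotoxicity, read by luminescence, with a stated time of 72 h (on this read-out lower numbers stand for an effect already at smaller amounts and higher numbers for an effect only at larger amounts of compound), compound 1 gives a reading that is a limit of the assay, > 21500 nM. Compound 2 `CCOC(=O)c1c(-c2cccc(OCC)c2)[nH]c2cc(OC)ccc2c1=O` is the next member; in this assay compound 2 gives only a limit as well, > 21500 nM. Compound 3 `CCOC(=O)c1c(-c2cccc(Oc3ccccc3)c2)[nH]c2cc(OC)ccc2c1=O` follows; in this assay compound 3 too gives only a limit, > 21500 nM. Compound 3 thus stands with the other two at the limit of > 21500 nM in this assay, at which 3 of the 3 values shown sit, and none of the three is set apart from another on the numbers shown. The steps between the measured compounds are a step that the two limits leave unreadable from compound 1 to compound 2, a step that the two limits leave unreadable from compound 1 to compound 3 and a step that the two limits leave unreadable from compound 2 to compound 3. Compound 4 `CCOC(=O)c1c(-c2cccc(N(C)C)c2)[nH]c2cc(OC)ccc2c1=O` is the compound not yet measured; it differs from compound 3 by dimethylamino in place of phenoxy on an aromatic carbon. The three measured steps bear on this change only in that every reading sits at the same limit, and none of them shows a step of readable size in either direction, so no movement beyond the scatter is expected in this assay, and a further limit is the more likely outcome. For compound 4 the expected step is a step that the limit leaves unreadable from compound 3 to compound 4. The estimate for compound 4 in this assay is 30000 nM, with a range from 15000 nM to 80000 nM.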

Compound 4, half-maximal effective concentration: > 21500 nM
Compound 4: only a limit was reported (the forecaster's own chance of this, stated with the estimate: 75%); the middle value does not contradict the limit.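

Among the compounds shown here, compound 4 yields only a limit, as do compound 1, compound 2 and compound 3, so no step to compound 4 can be read from any of them in this assay: the limit of > 21500 nM in this assay, at which 4 of the 4 values shown sit. The compounds shown leave open whether dimethylamino, phenoxy, ethoxy and methoxy differ at all in this assay, since none of the four has a readable value.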